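From fluoro to 4-methylpiperazin-1-yl on a shared core

The compounds below may be only part of what the source reports. "The series", "measured", "known", "first", "only" and "open" are said of these compounds alone.

- compound 1 (`COc1ccc(-c2cc(-c3ccc(C4NC(=O)c5ccccc5N4)cc3)nc(N)n2)cc1`) with 124000 nM as its result
- compound 2 (`Nc1nc(-c2ccc(F)cc2)cc(-c2ccc(C3NC(=O)c4ccccc4N3)cc2)n1`) with "not determined" (no result reported) as its result

Going by the values given here, the measure here is an ADME assay on Vero cells (Chlorocebus sabaeus) for cytotoxicity, read by MTT assay, with a stated time of 72 h (a higher number here means that more compound is tolerated, a lower number that less compound is tolerated), and it gives a number for only one of these two compounds. Compound 2 has no single number, so the step that follows has no measured starting point.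

Compound 3 (`CN1CCN(c2ccc(-c3cc(-c4ccc(C5NC(=O)c6ccccc6N5)cc4)nc(N)n3)cc2)CC1`) keeps the shared core and differs from compound 2 at one place: 4-methylpiperazin-1-yl in place of fluoro on an aromatic carbon, para to a large group (4-methylpiperazin-1-yl in place of fluoro on an aromatic carbon). Among the compounds with values here, the data hold no measured step for this kind of swap, so the only guide is compound 1, which carries the same core and reaches 124000 nM in this measure.

A modest step down from the level of compound 1 is expected, a little beyond the usual scatter and toward less compound being tolerated, though this is a loose expectation resting on one number. The estimate for compound 3 is 60000 nM (expected range from 15000 nM to 200000 nM).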

Compound 3, half-maximal cytotoxic concentration: 8320 nM
Beside the measured number, compound 3's estimate is 7.2-fold (0.86 log units) above it; measured number below the stated range.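

In this assay, placing 4-methylpiperazin-1-yl instead of methoxy on the aromatic carbon gives a 15-fold lower number from compound 1 to compound 3 (1.17 log units; beyond the scatter), a large change that shows the number at this position responds strongly to the group placed there. Going by these compounds alone, compound 2 has no number, and the swap from fluoro to 4-methylpiperazin-1-yl cannot be read, which leaves the step from methoxy as the only measured size of change at this position. Nothing in the data on hand explains the drop.

The compounds shown leave open whether the drop belongs to the piperazine ring as a whole or to the methyl group on it, and a plain piperazin-1-yl, a morpholin-4-yl ring or an open-chain dimethylamino group at the same place would help tell these apart. Within the data shown here, also open is whether the same swap would move the number by a similar amount on another core, as one pair of compounds gives only one step.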